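Fluoro for Chloro in the Lowest Compound

The source may report more compounds than this note shows. Statements on the series, on what has been measured and on what is new or still open speak of the compounds shown alone.

In a functional assay on PC-3 cells (Homo sapiens) for inhibition, read by MTT assay, with a stated time of 48 h, tested at 10 uM (a lower number here means less inhibition of growth, a higher number more inhibition of growth at the concentration tested), compound 3 `Cc1oc2c([C@H]3CCN(C)C[C@H]3O)c(O)cc(O)c2c(=O)c1C(O)c1c(Cl)cccc1Cl` gives 0%, the lowest number of the three measured, while compound 1 `Cc1oc2c([C@H]3CCN(C)C[C@H]3O)c(O)cc(O)c2c(=O)c1C(O)c1ccc([N+](=O)[O-])cc1` gives 24% and compound 2 `Cc1oc2c([C@H]3CCN(C)C[C@H]3O)c(O)cc(O)c2c(=O)c1C(O)c1ccccc1Br` gives 45%. Compound 4 `Cc1oc2c([C@H]3CCN(C)C[C@H]3O)c(O)cc(O)c2c(=O)c1C(O)c1c(F)cccc1Cl` has fluoro in place of chloro on an aromatic carbon, ortho to a large group (fluoro in place of chloro on an aromatic carbon). Going by the values given here, no measured step makes this exact change. The closest evidence is a number 45 percentage points lower from compound 2 to compound 3 (beyond the scatter) and a number 24 percentage points lower from compound 1 to compound 3 (beyond the scatter), both of which introduce the 2,6-dichlorophenyl group. Compound 4 keeps one chloro, so only a limited upward move is expected relative to compound 3, which gives 0%. The expected change is a number 14 percentage points higher from compound 3 to compound 4 (beyond the scatter). For compound 4 the estimated value is 14%, with an expected range of 0% to 38%.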

Compound 4, percent growth inhibition at one concentration: 0%
Estimate against measurement, compound 4: 14 percentage points above; the measured number falls inside the stated range.
By their numbers in this assay, from the lowest: compounds 3 and 4 (each within the scatter of the next); then compound 1; then compound 2.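

In this assay the step of no change at the digits printed from compound 3 to compound 4 (within the scatter) shows that fluoro in place of chloro on this ring does not lift the number. The 2-chloro-6-fluorophenyl group also stays well apart from the other two groups, with a number 45 percentage points lower from compound 2 to compound 4 (beyond the scatter) and a number 24 percentage points lower from compound 1 to compound 4 (beyond the scatter) as the steps. Nothing available explains this result.

As far as these compounds go, whether a 2,6-difluorophenyl group would behave in the same way remains open. So does the effect of an amine or a carboxylic acid on this ring.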